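The compounds below may be only part of what the source reports. "The series", "measured", "known", "first", "only" and "open" are said of these compounds alone.

Of the compounds shown here, three have been tested so far in an assay on HEK293-A cells for agonist activity at probable G-protein coupled receptor 34 (Mus musculus), with a stated time of 1.5 h; a higher number here means a larger maximal response, a lower number a smaller maximal response. Compound 1 `CCCCCCCCCCCOc1ccccc1CCC(=O)OCc1ccc(OP(=O)(O)OC[C@H](N)C(=O)O)cc1` is reported in this assay as "not active" (no number reported), with no number attached. Compound 2 `CCCCCCCC/C=C\CCCCCCCC(=O)O[C@H]1CCCO[C@@H]1COP(=O)(O)OC[C@H](N)C(=O)O` is reported in this assay as "not active" (no number reported), again with no number, so it cannot be placed on a numerical scale. Compound 3 `CCCCCCCCCCCOc1ccccc1CCC(=O)OC[C@H]1OCC=C[C@H]1OP(=O)(O)OC[C@H](N)C(=O)O` gives 5% in this assay. Among the measured compounds shown here, compound 2 thus stands among the entries without a number, and the only number in the set, from compound 3, is small. Compound 4 `CCCCCCCC/C=C\CCCCCCCC(=O)O[C@@H]1CCCO[C@@H]1COP(=O)(O)OC[C@H](N)C(=O)O` differs from compound 2 in that (the two compounds have the same atoms and bonds; at least one stereo element is drawn with a configuration in one of them and without one in the other: 1 of 5 stereo elements differ; a stereocentre at a saturated ring carbon is drawn S in compound 2 and R in compound 4). For the measured compounds named here, no step between measured compounds is available to indicate a direction, so no change beyond the usual scatter is expected in this assay. Compound 4 is expected to give about 5% in this assay, estimated between 0% and 15%.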

Compound 4, largest response reached (Emax), in percent of the reference or control that the assay uses: "not active" (no number reported)
For compound 4 the study gives words and no number; no gap can be computed for the estimate.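

Compound 2 and compound 4 are both reported as not active in this assay, so no step can be read between them. As far as these compounds go, whether the ring-carbon configuration affects the maximal response remains open.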